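The source may report more compounds than this note shows. Statements on the series, on what has been measured and on what is new or still open speak of the compounds shown alone.

Measured compounds:
- compound 1, `Cc1[nH]c2ccccc2c1C(c1ccccc1)c1cc2cc(C(C)(C)C)cc(C(C)(C)C)c2o1`: 72000 nM
- compound 2, `CC(C)(C)c1cc(C(C)(C)C)c2oc(C(c3ccccc3)c3c[nH]c4ccc([N+](=O)[O-])cc34)cc2c1`: 48200 nM

Both compounds share the same core and differ only in the indolyl group attached to a saturated chain carbon bound to two aromatic carbons. In a functional assay on SiHa cells (Homo sapiens) for cytotoxicity (on this read-out lower numbers stand for stronger inhibition and higher numbers for weaker inhibition), compound 2 gives the lower of the two numbers, but the step of a 1.5-fold lower number from compound 1 to compound 2 (0.17 log units; within the scatter) is within the scatter, so the two compounds cannot be told apart on cytotoxic strength.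

Compound 3 is `Cc1c(C(c2ccccc2)c2cc3cc(C(C)(C)C)cc(C(C)(C)C)c3o2)[nH]c2ccccc12`. It differs from compound 2 in that (3-methyl-1H-indol-2-yl in place of 5-nitro-1H-indol-3-yl on a saturated chain carbon bound to two aromatic carbons). Within the data shown here, this is again an exchange of one indolyl group for another at the same carbon, and the only measured step of that kind, a 1.5-fold lower number from compound 1 to compound 2 (0.17 log units; within the scatter), produced no change beyond the scatter. Nothing here suggests that this new exchange should do otherwise; a step of a 1.2-fold higher number from compound 2 to compound 3 (0.10 log units; within the scatter) is expected, that is, none beyond the scatter.

Compound 3 is therefore estimated at 60000 nM in this assay, with a range from 25000 nM to 150000 nM.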

Compound 3, half-maximal inhibitory concentration: > 100000 nM
Compound 3: no number, only a limit; the forecaster's own chance of this, stated with the estimate: 15%; middle value at least 1.6-fold (0.22 log units) away from the limit.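

In this assay the result for compound 3 is a limit of the assay and not a number, so any step that ends at it gives only a floor for the true size: the limit of > 100000 nM in this assay, at which 1 of the 3 values shown sits. Even so, the indolyl group on this saturated chain carbon is now seen to matter, since placing 3-methyl-1H-indol-2-yl where 5-nitro-1H-indol-3-yl stood gives an at least 2.0-fold higher number from compound 2 to compound 3 (0.31 log units; beyond the scatter), whereas the earlier exchange of indolyl groups stayed within the scatter. The comparison with the methyl-bearing compound is less clear: placing 3-methyl-1H-indol-2-yl where 2-methyl-1H-indol-3-yl stood gives an at least 1.3-fold higher number from compound 1 to compound 3 (0.14 log units; that floor lies within the scatter), so this pair shows no firm difference, and the real gap could be larger than that floor.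

The three compounds leave open which part of the exchange matters, since compound 2 and compound 3 differ both in the nitro and methyl groups and in how the indole is attached to the chain carbon. Also open, going by these compounds, is how this carbon would respond to a plain 1H-indol-3-yl group, or to an indole carrying an amine or a carboxylic acid.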